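From Ethyl to Isopropyl at the Top of the Scale

The source may hold more compounds than are shown below. What is called first, only, known or untested is meant among the compounds shown, and "the series" means these compounds.

Compound 1 `O=C(Nc1nn[nH]n1)c1cc(Cl)cc(-c2ccc(Cl)cc2)n1`: 11%
Compound 2 `CCc1ccc(-c2cc(Cl)cc(C(=O)Nc3nn[nH]n3)n2)cc1`: 100%

In a functional assay on the whole organism with Rattus norvegicus as the target, at a dose of 3 mg/kg by the oral route (on this read-out lower numbers stand for a weaker effect and higher numbers for a stronger effect at the one dose given), compound 1 gives 11%, while compound 2 gives 100%. Compound 2 therefore stands highest of the two numbers shown, and the only measured step, a number 89 percentage points higher from compound 1 to compound 2 (beyond the scatter), came with ethyl in place of chloro on an aromatic carbon.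

The next compound, compound 3 `CC(C)c1ccc(-c2cc(Cl)cc(C(=O)Nc3nn[nH]n3)n2)cc1`, differs from compound 2 by methyl in place of hydrogen on a saturated chain carbon bound to an aromatic carbon and a saturated chain carbon. No measured step concerns this kind of change: the one step shown swaps a chloro for an ethyl, not an ethyl for an isopropyl, so it gives only indirect guidance. What it does show is that the ethyl-bearing compound 2 sits at the very top of the read-out, leaving no room for a rise. A small extension of that same chain is expected to keep the effect strong, so the expected step is a number 10 percentage points lower from compound 2 to compound 3 (within the scatter), which is within the scatter or at most a modest drop. Compound 3 is estimated to give 90%, with a range from 60% to 100%.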

Compound 3, a percentage reported as inhibition, in the whole organism at one dose (the size of the read-out at that dose, not a potency): 68%
Compound 3: the middle estimate sits 22 percentage points above what was measured; low and high end bracket the measured number.
By their numbers in this assay, from the lowest: compound 1; then compound 3; then compound 2.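

Adding a single methyl on a saturated chain carbon bound to an aromatic carbon and a saturated chain carbon is not a neutral change in this assay and the ethyl to isopropyl swap brings a number 32 percentage points lower from compound 2 to compound 3 (beyond the scatter) even though only 1 heavy atom enters. The gain over chloro is not unique to ethyl, since the isopropyl group also brings a number 57 percentage points higher from compound 1 to compound 3 (beyond the scatter) while remaining short of what ethyl gives. No supporting measurement is available to explain why the branched group gives the lower number.

The compounds shown leave open how the read-out would respond to a smaller methyl, an unbranched propyl, or a more heavily branched tert-butyl, so two chain groups and one branched group cannot yet define a trend at this position. They also leave open how far apart compound 2 and compound 3 would lie at other doses, since each number here describes the size of the effect at one oral dose and is not a potency.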